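This account rests on a few compounds, and the source may have more. Where it says the series, first, only, none or still open, it means among the compounds named here.

Going by the values given here, compound 1 `O=C1O[C@H]([C@@H](O)Cn2cc(-c3ccc(Br)cc3)nn2)C(OCc2ccccc2)=C1OCc1ccccc1` gives 5070 nM in a functional assay on HepG2 cells (Homo sapiens) for antiproliferative activity, read by MTT assay, with a stated time of 72 h (a lower number here means a stronger inhibitor, a higher number a weaker inhibitor), and is the only compound here with a number rather than a limit. For compound 2 `O=C1O/C(=C\Cn2cc(-c3cc(F)cc(F)c3)nn2)C(OCc2ccccc2)=C1OCc1ccccc1` this assay reports only a limit, > 100000 nM, which is the limit of > 100000 nM in this assay, at which 1 of the 2 values shown sits. Compound 3 `Cc1ccc(-c2cn(C[C@H](O)[C@H]3OC(=O)C(OCc4ccccc4)=C3OCc3ccccc3)nn2)cc1` differs from compound 1 by methyl in place of bromo on an aromatic carbon. Among the compounds with values here, no pair of measured compounds shows a change of this kind on its own, so its size is untested here; the expected step is a 1.4-fold higher number from compound 1 to compound 3 (0.14 log units; within the scatter), no larger than the usual scatter or slightly toward weaker inhibition. For compound 3 the estimate in this assay is 7000 nM, with a range from 2500 nM to 20000 nM.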

Compound 3, half-maximal inhibitory concentration: 8770 nM
Beside the measured number, compound 3's estimate is 1.3-fold (0.10 log units) below it; low and high end bracket the measured number.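

In this assay, methyl in place of bromo on the aromatic carbon gives a 1.7-fold higher number from compound 1 to compound 3 (0.24 log units; within the scatter). Going by these compounds alone, this is the first step read at this place, and it shows that the change from 4-bromophenyl to 4-methylphenyl leaves the number within the scatter, so the two groups cannot be told apart here. Nothing available bears on the cause of this step.

Still open, from the compounds shown here alone, is whether a group of another kind at this place, such as an amine or a carboxylic acid, would move the number beyond the scatter. A longer chain in place of methyl is equally untested by these compounds.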